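This account rests on a few compounds, and the source may have more. Where it says the series, first, only, none or still open, it means among the compounds named here.

Values in an ADME assay on BJ cells (Homo sapiens) for cytotoxicity, with a stated time of 72 h; on this read-out higher numbers stand for an effect only at larger amounts of compound and lower numbers for an effect already at smaller amounts:
- Compound 1 `C=C[C@@](C)(/C=C/c1ccc(O)c(/C=C/C(=O)c2ccccc2)c1)CCC=C(C)C`: > 20000 nM (a limit)
- Compound 2 `C=C[C@@](C)(/C=C/c1ccc(O)c(/C=C/c2ccc(Cl)cc2)c1)CCC=C(C)C`: > 36600 nM (a limit)

Compound 2 has no number on this read-out, and its > 36600 nM is a limit. For the measured compounds named here, compound 1 likewise stands at a limit, so the only measured step is a step that the two limits leave unreadable from compound 1 to compound 2.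

The next structure is compound 3 `C=C[C@@](C)(/C=C/c1ccc(O)c(/C=C/c2ccc(Cl)c(Cl)c2)c1)CCC=C(C)C`. The change is chloro in place of hydrogen on an aromatic carbon, taking 4-chlorophenyl to 3,4-dichlorophenyl. Going by the values given here, the one measured step gives no size to carry over, so no step beyond the scatter is expected in this assay, and no direction is favoured. The step expected from this estimate is an at least 1.0-fold lower number from compound 2 to compound 3 (0.01 log units; that floor lies within the scatter), and a further limit is the likeliest report. For compound 3 the estimated value is 35000 nM, with an expected range of 15000 nM to 60000 nM.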

Compound 3, half-maximal effective concentration: > 13000 nM
Compound 3: only a limit was reported; the forecaster's own chance of this, stated with the estimate: 80%; the middle value does not contradict the limit.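

In this assay compound 3 gives > 13000 nM, which is a limit. For the compounds shown here, compound 1, compound 2 and compound 3 all stand at limits, so no step among them can be read. On these data alone, the size and direction of any difference between these three compounds remain open.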